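Sulfonamide nitrogen substituent swap in the aryl-alkyne series

This account rests on a few compounds, and the source may have more. Where it says the series, first, only, none or still open, it means among the compounds named here.

Measured so far in an assay on CHO cells for displacement of a labelled ligand from prostaglandin D2 receptor 2 (Homo sapiens), read by scintillation counting; a lower number here means a stronger inhibitor, a higher number a weaker inhibitor:
- compound 1 `CC(C)c1ccc(S(C)(=O)=O)cc1C#Cc1cc(C#N)ccc1OCC(=O)O`: 12 nM
- compound 2 `CN(C)C(=O)c1cccc(C#Cc2cc(Cl)ccc2OCC(=O)O)c1`: 52 nM
- compound 3 `COCCN(C)S(=O)(=O)c1ccc(C)c(C#Cc2cc(Cl)ccc2OCC(=O)O)c1`: 4.1 nM

Compound 3 holds the lowest of the three numbers in this assay; compound 1 lies nearest to it and compound 2 furthest, both beyond the scatter. Compound 4 `Cc1ccc(S(=O)(=O)N(C)C(C)C)cc1C#Cc1cc(Cl)ccc1OCC(=O)O` is unmeasured. It differs from compound 3 by isopropyl in place of 2-methoxyethyl on a sulfonamide nitrogen. Among the compounds with values here, no step between measured compounds isolates this kind of change, so the expectation rests on compound 3 alone. The expected step from compound 3 to compound 4 in this assay is a 1.5-fold higher number from compound 3 to compound 4 (0.17 log units; within the scatter), small and not clearly beyond the scatter, with the number possibly drifting slightly higher. Compound 4 is estimated at 6 nM, within a range of 2 nM to 18 nM.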

Compound 4, inhibition constant: 3.8 nM
The estimate for compound 4 lay 1.6-fold (0.20 log units) above the measured number, within the range that was stated.
By their numbers in this assay, from the lowest: compounds 4 and 3 (each within the scatter of the next); then compound 1; then compound 2.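

In this assay, within the data shown here, isopropyl in place of 2-methoxyethyl on the sulfonamide nitrogen gives a 1.1-fold lower number from compound 3 to compound 4 (0.03 log units; within the scatter) and so gives the first matched step at this position. The oxygen of the 2-methoxyethyl chain, the one hydrogen-bond acceptor that leaves, is therefore not needed to keep the number at this level in this pair. No measured data bear on why the two groups read alike.

Open, as far as these compounds go, is how far this position tolerates other groups, such as a longer chain like 3-methoxypropyl, a 2-aminoethyl chain or a carboxylic acid on the chain. Also open, from the compounds shown here alone, is whether the same swap reads alike on the nitrile-bearing core of compound 1.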